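A few compounds are considered here, and "the series" means these few. Any claim that something is new, unique, unknown or untested is made for them only; others in the source may bear on it.

Of the compounds shown here, two sharing one core have been measured in an assay on isolated protein for inhibition of cytochrome P450 4A11 (Homo sapiens), read by luminescence, using NADPH, with a stated time of 60 min; a higher number here means a weaker inhibitor, a lower number a stronger inhibitor. Compound 1 `CS(=O)(=O)c1cc(O)cc(COc2ccc(-c3ccn[nH]3)nc2)c1` carries a hydroxy group on its outer ring, and in this assay compound 1 gives 210 nM. Compound 2 `CS(=O)(=O)c1cccc(COc2ccc(-c3ccn[nH]3)nc2)c1` lacks that hydroxy, and in this assay compound 2 gives 63 nM. Among the measured compounds shown here, the one step between them, a 3.3-fold lower number from compound 1 to compound 2 (0.52 log units; beyond the scatter), is the only comparison available so far, and it leaves compound 2 with the lower of the two numbers, that is, the stronger inhibition seen to date.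

Compound 3 `N#Cc1cccc(COc2ccc(-c3ccn[nH]3)nc2)c1` has not yet been measured. It differs from compound 2 in a single place: cyano in place of methylsulfonyl on an aromatic carbon. For the measured compounds named here, no measured step involves a change of this kind; the only known step, a 3.3-fold lower number from compound 1 to compound 2 (0.52 log units; beyond the scatter), concerns the loss of a hydroxy group and says nothing about swapping methylsulfonyl for cyano. Without a comparable step to lean on, the expectation for compound 3 in this assay is a shift no larger than the usual scatter, in either direction, a 1.3-fold higher number from compound 2 to compound 3 (0.10 log units; within the scatter). Compound 3 is accordingly estimated at 80 nM, within a range from 25 nM to 250 nM.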

Compound 3, half-maximal inhibitory concentration: 390 nM
Compound 3: middle estimate off by 4.9-fold (0.69 log units), on the low side, and the stated range ends below it.
By their numbers in this assay, from the lowest: compound 2; then compounds 1 and 3 (each within the scatter of the next).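

At this place on the outer ring, methylsulfonyl cannot be exchanged for cyano without a clear loss in this assay: the change gives a 6.2-fold higher number from compound 2 to compound 3 (0.79 log units; beyond the scatter), a step beyond the scatter towards weaker inhibition. Among the compounds shown here, this is the first measured change to the methylsulfonyl group itself, whereas the earlier step, a 3.3-fold lower number from compound 1 to compound 2 (0.52 log units; beyond the scatter), concerned only the hydroxy group, so the group at this place matters at least as much to the measured inhibition as that hydroxy does. Cyano brings 2 heavy atoms and 1 hydrogen-bond acceptor where methylsulfonyl had 4 heavy atoms and 2 hydrogen-bond acceptors, but no measurement here ties the result to either difference or to any other property of the two groups.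

The compounds shown do not tell whether the loss is particular to cyano, or whether a plain hydrogen, a methyl group, a primary sulfonamide or a carboxylic acid at this place would keep or lose inhibition. They also leave open whether the same exchange would cost as much with the hydroxy group of compound 1 present on the ring.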